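Swapping a hexyl chain for a methoxyphenyl ring

The source may report more compounds than this note shows. Statements on the series, on what has been measured and on what is new or still open speak of the compounds shown alone.

Compound 1, `CCCCCc1nc(N)n(CC(=O)Nc2ccccc2)c1-c1ccccc1Br`: in a functional assay on A-375 cells (Homo sapiens) for antiproliferative activity, read by MTT assay, with a stated time of 48 h (on this read-out lower numbers stand for stronger inhibition and higher numbers for weaker inhibition), compound 1 gives 26400 nM.
Compound 2, `CCCCCCCc1nc(N)n(CC(=O)Nc2ccccc2)c1-c1ccccc1Br`: in this assay compound 2 gives 9200 nM.
Compound 3, `CCCCCCCc1nc(N)n(CC(=O)Nc2ccc(C)cc2)c1-c1ccccc1Br`: in this assay compound 3 gives 5200 nM.

Compound 3 carries the lowest number of the three; its gap to compound 2 lies within the scatter, while its gap to compound 1 lies beyond it. Compound 4, `COc1ccc(Cc2nc(N)n(CC(=O)Nc3ccc(C)cc3)c2-c2ccccc2Br)cc1`, differs from compound 3 by 4-methoxyphenyl in place of hexyl on a saturated chain carbon bound to an aromatic carbon. Two measured steps offer a loose guide. a 2.9-fold lower number from compound 1 to compound 2 (0.46 log units; beyond the scatter) shows that lengthening the chain helped, and a 1.8-fold lower number from compound 2 to compound 3 (0.25 log units; within the scatter) stayed within the scatter. For the measured compounds named here, neither step exchanges a chain for an aromatic ring, so no direct precedent exists. Since the only clear gain came from a longer chain, cutting the chain back to a single saturated carbon carrying a ring is expected to give no step beyond the scatter, or at most a small one toward weaker inhibition, a 1.3-fold higher number from compound 3 to compound 4 (0.10 log units; within the scatter). Compound 4 is therefore estimated at 6500 nM in this assay, within a range from 1500 nM to 28000 nM.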

Compound 4, half-maximal inhibitory concentration: 2400 nM
Compound 4: middle estimate off by 2.7-fold (0.43 log units), on the high side; the range from low to high includes it.
By their numbers in this assay, from the lowest: compound 4; then compounds 3 and 2 (each within the scatter of the next); then compound 1.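

At this position a long saturated chain is not needed for a lower number: exchanging hexyl for 4-methoxyphenyl on a saturated chain carbon bound to an aromatic carbon gives a 2.2-fold lower number from compound 3 to compound 4 (0.34 log units; beyond the scatter). The earlier compounds shown here carried only saturated chains there, and the one clear gain among them came with a longer chain, whereas heptyl to 4-methoxybenzyl shows that a ring-bearing group can also be accepted at this position in this assay. Nothing measured here explains why the number falls.

The change brings in the aromatic ring and the methoxy group together, so these compounds cannot show how much each one contributes. Going by these compounds, a plain benzyl group, a 4-chlorobenzyl group or a 4-hydroxybenzyl group at the same place could begin to separate the two, and that question remains open.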